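Fluoro for Cyano on the Distal Phenyl Ring

The source may hold more compounds than are shown below. What is called first, only, known or untested is meant among the compounds shown, and "the series" means these compounds.

Of the compounds shown here, three sharing one core have been tested in a toxicity assay on MT4 cells (Homo sapiens) for cytotoxicity, read by MTT assay, with a stated time of 5 days; on this read-out higher numbers stand for lower toxicity in this test and lower numbers for higher toxicity in this test. Compound 1 `N#C/C=C/c1cc(F)c(Oc2nc(Nc3ccc(C#N)c(F)c3)nc3sccc23)c(F)c1` gives 117000 nM. Compound 2 `Cc1cc(-c2ccc(C#N)cc2)cc(C)c1Oc1nc(Nc2ccc(C#N)c(F)c2)nc2ccsc12` gives 71500 nM. Compound 3 `Cc1cc(-c2ccc(C#N)cc2)cc(C)c1Oc1nc(Nc2ccc(C#N)nc2)nc2ccsc12` gives 214000 nM. Compound 2 stands lowest of the three numbers, with compound 1 within the scatter of it, whereas a 3.0-fold higher number from compound 2 to compound 3 (0.48 log units; beyond the scatter) lies beyond the scatter. Compound 4 `Cc1cc(-c2ccc(F)cc2)cc(C)c1Oc1nc(Nc2ccc(C#N)c(F)c2)nc2ccsc12` differs from compound 2 by fluoro in place of cyano on an aromatic carbon. Within the data shown here, the only measured step alters the ring on the nitrogen, not the ring that carries the cyano, so no measured step bears directly on this change, and no step beyond the scatter is expected. Compound 4 is therefore estimated at 80000 nM in this assay, within 35000 nM to 180000 nM. The expected step is a 1.1-fold higher number from compound 2 to compound 4 (0.05 log units; within the scatter).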

Compound 4, half-maximal cytotoxic concentration: 97300 nM
Compound 4: middle estimate off by 1.2-fold (0.09 log units), on the low side; the measured number falls inside the stated range.
By their numbers in this assay, from the lowest: compounds 2, 4, 1 and 3 (each within the scatter of the next, the first and the last beyond it).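

In this assay, the change from 4-cyanophenyl to 4-fluorophenyl gives a 1.4-fold higher number from compound 2 to compound 4 (0.13 log units; within the scatter), so at this position the nitrile and the fluoro cannot be told apart in this test. Among these compounds, the earlier step, a 3.0-fold higher number from compound 2 to compound 3 (0.48 log units; beyond the scatter), concerned the ring on the nitrogen, so this is the only reading at this position. No measurement shown here accounts for the result. On these data alone, whether an amine or a carboxylic acid at this position would also stay within the scatter of compound 2 remains open. So does whether the same exchange reads alike with the 6-cyanopyridin-3-yl of compound 3 on the nitrogen.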